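Replacing Bromo with Methyl in Compound 3

A few compounds are considered here, and "the series" means these few. Any claim that something is new, unique, unknown or untested is made for them only; others in the source may bear on it.

In a functional assay on DU-145 cells (Homo sapiens) for inhibition, read by trypan blue exclusion, with a stated time of 96 h (on this read-out higher numbers stand for weaker inhibition of growth and lower numbers for stronger inhibition of growth), compound 1 `COc1ccccc1/C=C(\C(=O)c1ccc(Br)cc1)S(=O)(=O)c1ccc(C)cc1` gives 1000 nM and compound 2 `Cc1ccc(S(=O)(=O)/C(=C/c2sccc2C)C(=O)c2ccc(Br)cc2)cc1` gives 25000 nM while compound 3 `O=C(/C(=C\c1ccc(Br)cc1)S(=O)(=O)c1ccc(Br)cc1)c1ccc(Br)cc1` gives 10000 nM and so lies between the other two. Compound 4 `Cc1ccc(S(=O)(=O)/C(=C/c2ccc(Br)cc2)C(=O)c2ccc(Br)cc2)cc1` has not yet been measured. It differs from compound 3 by methyl in place of bromo on an aromatic carbon in a change from 4-bromophenyl to 4-methylphenyl. Within the data shown here, the only measured step of a 25-fold higher number from compound 1 to compound 2 (1.40 log units; beyond the scatter) is large but lies at a different place, so it offers no direct guide to this swap. The expected step of a 1.3-fold lower number from compound 3 to compound 4 (0.10 log units; within the scatter) in this assay is therefore none beyond the scatter. Compound 4 is estimated at 8000 nM with an expected range from 2500 nM to 25000 nM on this read-out.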

Compound 4, concentration for 50% growth inhibition: 10000 nM
Compound 4: the middle estimate sits 1.3-fold (0.10 log units) below what was measured, and the stated range covers the measured number.
By their numbers in this assay, from the lowest: compound 1; then compounds 3 and 4 (each within the scatter of the next); then compound 2.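

In this assay, methyl in place of bromo on an aromatic carbon, para to a large group, gives no change at the digits printed from compound 3 to compound 4 (within the scatter), so the two groups cannot be told apart at this position. With that methyl in place, the group on the double-bonded chain carbon can be compared twice: a 2.5-fold lower number from compound 2 to compound 4 (0.40 log units; beyond the scatter) and a 10-fold higher number from compound 1 to compound 4 (1.00 log units; beyond the scatter), which ranks 4-bromophenyl behind 2-methoxyphenyl and ahead of 3-methylthiophen-2-yl. No evidence is available that explains these steps.

As far as these compounds go, it remains open whether an amine or a carboxylic acid at this position would also leave the number unchanged. From the compounds shown here alone, it is also open whether the bromo-to-methyl swap would stay silent with 2-methoxyphenyl on the chain carbon.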